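Swapping fluoro for chloro on the phenyl ring

This account rests on a few compounds, and the source may have more. Where it says the series, first, only, none or still open, it means among the compounds named here.

Measured so far:
- compound 1 `c1ccc(-c2cn3ccnc3c(-c3ccc4ncn(C5CCCCC5)c4c3)n2)cc1`: 28.7%
- compound 2 `Fc1ccc(-c2cn3ccnc3c(-c3ccc4ncn(C5CCCCC5)c4c3)n2)cc1`: 1.78%

In a functional assay on MDA-MB-435 cells (Homo sapiens) for inhibition, read by sulforhodamine B assay, with a stated time of 48 h, tested at 10 uM (on this read-out lower numbers stand for less inhibition and higher numbers for more inhibition at the one concentration tested (going by the name of the read-out)), compound 1 gives 28.7%, while compound 2 gives 1.78%. Going by the values given here, compound 2 thus holds the lowest of the two numbers, and the only other compound, compound 1, sits higher by the step of a number 26.9 percentage points lower from compound 1 to compound 2 (beyond the scatter), a change of fluoro in place of hydrogen on an aromatic carbon.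

Compound 3 `Clc1ccc(-c2cn3ccnc3c(-c3ccc4ncn(C5CCCCC5)c4c3)n2)cc1` has not been measured. It differs from compound 2 in one place: chloro in place of fluoro on an aromatic carbon. Among the compounds with values here, no measured step exchanges one halogen for another, so the single known step of a number 26.9 percentage points lower from compound 1 to compound 2 (beyond the scatter) bears on the question only indirectly, as it shows that a substituent at this aromatic carbon moved the number downward. A halogen therefore stays in place in compound 3, and the expectation is a step from compound 2 that stays within the scatter, a number 8.2 percentage points higher from compound 2 to compound 3 (within the scatter). Compound 3 is estimated at 10%, with a range from -8% to 32%.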

Compound 3, a percentage reported as inhibition, at one concentration (the size of the read-out at that concentration, not a potency): 36.7%
Compound 3: middle estimate off by 26.7 percentage points, on the low side; measured number outside the range, above it.
By their numbers in this assay, from the lowest: compound 2; then compounds 1 and 3 (each within the scatter of the next).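

In this assay the choice of halogen matters at this position: there is a number 34.9 percentage points higher from compound 2 to compound 3 (beyond the scatter) and so 4-fluorophenyl and 4-chlorophenyl cannot be treated as interchangeable here. The earlier step might have suggested that any substituent on this aromatic carbon lowers the number, yet chloro in place of hydrogen gives a number 8 percentage points higher from compound 1 to compound 3 (within the scatter) and so, among the compounds shown, only fluoro goes with the drop. Nothing measured here explains why the two halogens differ.

As far as these compounds go, whether a bromo group, a methoxy group or an amine at this place would read like chloro or like fluoro remains open. Also open, from the compounds shown here alone, is whether the gap between these compounds holds at concentrations other than the single one tested.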